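The compounds below may be only part of what the source reports. "The series", "measured", "known", "first", "only" and "open" are said of these compounds alone.

Measured so far in a functional assay on ECa-109 cells (Homo sapiens) for cytotoxicity, read by MTT assay, with a stated time of 48 h; on this read-out lower numbers stand for stronger inhibition and higher numbers for weaker inhibition:
Compound 1 `COc1cc(C(C2=C(O)C(=O)c3ccccc3C2=O)c2c[nH]c3ccc(Br)cc23)cc(OC)c1OC` gives 13000 nM.
Compound 2 `COc1ccccc1C(C1=C(O)C(=O)c2ccccc2C1=O)c1c[nH]c2ccccc12` reaches only the limit of the assay, > 200000 nM.
Compound 3 `O=C1C(O)=C(C(c2ccc([N+](=O)[O-])cc2)c2c[nH]c3ccccc23)C(=O)c2ccccc21` gives 60900 nM.

Among the two numbers shown, compound 3 stands highest, with compound 1 the nearest and lower. Among the measured compounds shown here, the one measured step that changes a single place is an at least 3.2-fold lower number from compound 2 to compound 3 (0.51 log units; beyond the scatter); its size is a minimum only, since compound 2 sits at the limit of > 200000 nM in this assay, at which 1 of the 3 values shown sits.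

Compound 4 `O=C1C(O)=C(C(c2ccc([N+](=O)[O-])cc2)c2c[nH]c3ccc(Br)cc23)C(=O)c2ccccc21` differs from compound 3 by bromo in place of hydrogen on an aromatic carbon. For the measured compounds named here, no measured pair isolates this change: compound 1 carries the bromo and gives the lowest number in the set, but it also carries a different aryl group, so its gap to compound 3 cannot be read as the bromo alone. The step from compound 2 to compound 3 concerns the aryl group and says nothing about the indole position. With no direct comparison available, the bromo is expected to move the number only modestly, if at all, and the direction is taken from compound 1 as a weak hint towards a lower number.

Compound 4 is therefore expected to give about 30000 nM in this assay, within 10000 nM to 90000 nM, which means an expected step of a 2.0-fold lower number from compound 3 to compound 4 (0.31 log units; beyond the scatter).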

Compound 4, half-maximal inhibitory concentration: 16900 nM
Beside the measured number, compound 4's estimate is 1.8-fold (0.25 log units) above it; the measured number falls inside the stated range.
By their numbers in this assay, from the lowest: compounds 1 and 4 (each within the scatter of the next); then compound 3. At a limit, above all of these: compound 2.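

In this assay, among the compounds shown here, the exchange of 1H-indol-3-yl for 5-bromo-1H-indol-3-yl with the 4-nitrophenyl group held constant gives a 3.6-fold lower number from compound 3 to compound 4 (0.56 log units; beyond the scatter) and so provides the first direct reading of bromo in place of hydrogen on this aromatic carbon. Until now bromo stood only in compound 1, which had no matched partner carrying hydrogen, so the contribution of this position could not be separated from that of the aryl group. For the compounds shown here, with the 5-bromo-1H-indol-3-yl group held constant, the aryl exchange gives a 1.3-fold higher number from compound 1 to compound 4 (0.11 log units; within the scatter) and does not separate 4-nitrophenyl from 3,4,5-trimethoxyphenyl on this background, which differs from the single reading available for an aryl change on the unsubstituted indole.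

No measurement shown bears on the reason for the bromo step. As far as these compounds go, the bromo step rests on a single pair, so it remains open whether it recurs with 3,4,5-trimethoxyphenyl or 2-methoxyphenyl in place of 4-nitrophenyl, and what chloro or an amine would do on the same aromatic carbon.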